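The compounds below may be only part of what the source reports. "The series", "measured", "known", "first", "only" and "open" are said of these compounds alone.

Measured so far:
compound 1 `CCC(=O)Oc1ccc2oc(/C=C/[S+](C)[O-])cc(=O)c2c1` — 9000 nM
compound 2 `COc1cccc2oc(/C=C/[S+](C)[O-])cc(=O)c12` — > 10000 nM

In a functional assay on DLD-1 cells (Homo sapiens) for cytotoxicity, with a stated time of 48 h (on this read-out higher numbers stand for weaker inhibition and lower numbers for stronger inhibition), compound 1 gives 9000 nM. For compound 2 the reading of > 10000 nM is a limit of the assay, not a number; this is the limit of > 10000 nM in this assay, at which 1 of the 2 values shown sits. Among the measured compounds shown here, compound 1 therefore stands on the only number given in this assay, with the remaining value a limit, so no measured step between compounds 1 and 2 can be sized.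

Compound 3 `C[S+]([O-])/C=C/c1cc(=O)c2cc(O)ccc2o1` is not yet measured. It differs from compound 1 by hydrogen in place of propanoyl on an oxygen on an aromatic ring. For the measured compounds named here, no measured pair covers this change, so nothing fixes its direction or size.

The expected step of a 1.1-fold higher number from compound 1 to compound 3 (0.05 log units; within the scatter) is no larger than the usual scatter. Compound 3 is therefore expected near 10000 nM, within 3500 nM to 30000 nM, with a real chance that this assay returns only a limit for compound 3.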

Compound 3, half-maximal inhibitory concentration: > 10000 nM
Compound 3: a limit, no number; the forecaster's own chance of this, stated with the estimate: 50%; the middle value lies on the limit itself.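

In this assay, among the compounds shown here, the pair gives the first reading on this oxygen on an aromatic ring: hydrogen in place of propanoyl yields an at least 1.1-fold higher number from compound 1 to compound 3 (0.04 log units; that floor lies within the scatter). The reading for compound 3, > 10000 nM, is a limit of the assay and not a number. The pair therefore gives only a floor, which fixes neither the direction nor the size of the change beyond the scatter, and the series now sits mostly at the same ceiling: the limit of > 10000 nM in this assay, at which 2 of the 3 values shown sit.

Still open, from the compounds shown here alone, is the true size of the step from propanoyloxy to hydroxy, which needs a number for the hydroxy compound under a wider range of concentrations. Also open, going by these compounds, is how another group on this oxygen, such as acetyl or the longer hexanoyl chain, would read against compound 1.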